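A Chlorostyryl Group Added to a Series Stuck at the Limit

A few compounds are considered here, and "the series" means these few. Any claim that something is new, unique, unknown or untested is made for them only; others in the source may bear on it.

In a functional assay on EC9706 cells (Homo sapiens) for cytotoxicity, read by MTT assay, with a stated time of 72 h (a lower number here means a stronger inhibitor, a higher number a weaker inhibitor), three compounds built on a shared core have been measured, and none of them gave a number. Compound 1 `COc1ccc(NC(=O)CSC(=S)N[C@H]2CCOC2=O)cc1` reaches only the limit > 128000 nM in this assay. Compound 2 `O=C(CSC(=S)N[C@H]1CCOC1=O)Nc1ccc(O)cc1` likewise reaches only the limit > 128000 nM. Compound 3 `CC(=O)c1ccc(NC(=O)CSC(=S)N[C@H]2CCOC2=O)cc1` also stops at the limit > 128000 nM. The steps between them, a step that the two limits leave unreadable from compound 1 to compound 2, a step that the two limits leave unreadable from compound 1 to compound 3 and a step that the two limits leave unreadable from compound 2 to compound 3, cannot be read in size or direction since (the limit of > 128000 nM in this assay, at which 3 of the 3 values shown sit). Compound 3 therefore stands exactly where every measured value stands, at the limit, with nothing known to be stronger or weaker than it.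

Compound 4 `O=C(CSC(=S)N[C@H]1CCOC1=O)Nc1ccc(C(=O)/C=C/c2ccccc2Cl)cc1` differs from compound 3 by 2-(2-chlorophenyl)ethenyl in place of methyl on a carbonyl carbon. Within the data shown here, none of the measured steps touches this part of the molecule, and all three are unreadable, so they offer no measured guide to the size or direction of the step in this assay. The expected step of an at least 6.4-fold lower number from compound 3 to compound 4 (0.80 log units; beyond the scatter) is thus an estimate without a measured anchor. Compound 4 is expected to give about 20000 nM in this assay, within a range from 3000 nM to 128000 nM, with a real chance that it too stops at the limit.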

Compound 4, half-maximal inhibitory concentration: 34100 nM
Estimate against measurement, compound 4: 1.7-fold (0.23 log units) below; low and high end bracket the measured number.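

In this assay, putting 2-(2-chlorophenyl)ethenyl in place of methyl on the carbonyl carbon gives an at least 3.7-fold lower number from compound 3 to compound 4 (0.57 log units; beyond the scatter). Among these compounds, this is the first readable change, and it shows that this position can move a compound off the limit, which the swaps among hydroxy, methoxy and acetyl on the aromatic carbon could not show. The step is only a minimum, and its true size remains unknown: the limit of > 128000 nM in this assay, at which 3 of the 4 values shown sit.

The compounds shown do not separate the contributions of the chlorine, the double bond and the aromatic ring within the new group. They also leave open what a fluorine in place of that chlorine, or an amine or a carboxylic acid on that ring, would do in this assay.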